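Pyridin-4-yl for methylsulfonylphenyl: what inhibition to expect

The compounds below may be only part of what the source reports. "The series", "measured", "known", "first", "only" and "open" are said of these compounds alone.

Of the compounds shown here, three built on one shared core have been tested in a functional assay on Hep 3B2 cells (Homo sapiens) for inhibition, read by sulforhodamine B assay, with a stated time of 72 h, tested at 10 uM; a higher number here means more inhibition at the concentration tested (going by the name of the read-out), a lower number less inhibition. Compound 1 `C[C@H](Nc1ncnc2[nH]cnc12)c1nn(-c2cccc(F)c2)c2cc(F)ccc12` gives 28%. Compound 2 `C[C@H](Nc1ncnc2[nH]cnc12)c1nn(-c2cccnc2)c2cc(F)ccc12`, with pyridin-3-yl in place of 3-fluorophenyl on an aromatic nitrogen, gives 20%, a change of a number 8 percentage points lower from compound 1 to compound 2 (within the scatter). Compound 3 `C[C@H](Nc1ncnc2[nH]cnc12)c1nn(-c2cccc(S(C)(=O)=O)c2)c2cc(F)ccc12` gives 11%, the lowest of the three numbers; the step of a number 9 percentage points lower from compound 2 to compound 3 (within the scatter) keeps it within the scatter of its nearest neighbour, while the step of a number 17 percentage points lower from compound 1 to compound 3 (beyond the scatter) separates it from compound 1.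

Among the measured compounds shown here, compound 4 `C[C@H](Nc1ncnc2[nH]cnc12)c1nn(-c2ccncc2)c2cc(F)ccc12` has no measurement yet. The change from compound 3 is pyridin-4-yl in place of 3-(methylsulfonyl)phenyl on an aromatic nitrogen. The measured step that bears most on this is a number 9 percentage points lower from compound 2 to compound 3 (within the scatter), which runs the opposite way: there a pyridin-3-yl gave way to the very group that now leaves, and pyridin-4-yl is a close relative of pyridin-3-yl. The step of a number 8 percentage points lower from compound 1 to compound 2 (within the scatter) adds that a pyridyl group and a 3-fluorophenyl group on this aromatic nitrogen gave numbers within the scatter of each other. Compound 4 is therefore expected to show a step of a number 9 percentage points higher from compound 3 to compound 4 (within the scatter), which would stay within the usual scatter. The estimate for compound 4 is 20%, from 8% to 32%.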

Compound 4, a percentage reported as inhibition, at one concentration (the size of the read-out at that concentration, not a potency): 5%
Compound 4: the middle estimate sits 15 percentage points above what was measured, outside the stated range (below it).
By their numbers in this assay, from the lowest: compounds 4, 3, 2 and 1 (each within the scatter of the next, the first and the last beyond it).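

In this assay, among the compounds shown here, the two pyridyl groups differ only in where the ring nitrogen sits, yet pyridin-4-yl in place of pyridin-3-yl gives a number 15 percentage points lower from compound 2 to compound 4 (beyond the scatter) and so shows that this position can register that small shift, which no earlier pair could reveal. Set against the 3-fluorophenyl compound, the new group gives a number 23 percentage points lower from compound 1 to compound 4 (beyond the scatter) on the same aromatic nitrogen, whereas the comparison with 3-(methylsulfonyl)phenyl gives a number 6 percentage points lower from compound 3 to compound 4 (within the scatter) and leaves those two compounds unresolved despite their quite different groups. Nothing in the available data explains why the two pyridyl groups part in this way.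

Still open, going by these compounds, is how a pyridin-2-yl group, or a phenyl ring carrying an amine or a carboxylic acid, would read on this aromatic nitrogen, which would show whether the effect follows the place of the ring nitrogen or something else about the group. Each number here also comes from a single concentration, so the potency of these compounds and the size of the gap between them at other concentrations remain unknown.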